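The source may report more compounds than this note shows. Statements on the series, on what has been measured and on what is new or still open speak of the compounds shown alone.

Measured compounds:
compound 1, `O=C(COc1ccc2cc(C(O)(C(F)(F)F)C(F)(F)F)c(O)cc2c1)Nc1ccc(-c2ccccc2)cc1`: 2800 nM
compound 2, `Oc1c(C(O)(C(F)(F)F)C(F)(F)F)ccc2ccccc12`: > 500000 nM

The study concerns an assay on isolated protein for inhibition of tyrosine-protein phosphatase non-receptor type 13 (Homo sapiens), read by spectrophotometry; a lower number here means a stronger inhibitor, a higher number a weaker inhibitor. Of the compounds shown here, two have been measured. Going by the values given here, compound 1, `O=C(COc1ccc2cc(C(O)(C(F)(F)F)C(F)(F)F)c(O)cc2c1)Nc1ccc(-c2ccccc2)cc1`, is the only one that gives a number in this assay, 2800 nM. Compound 2, `Oc1c(C(O)(C(F)(F)F)C(F)(F)F)ccc2ccccc12`, is a smaller compound that carries the core of compound 1 without the ether-linked amide arm; for compound 2 this assay reports only a limit, > 500000 nM. Among the compounds with values here, the picture of the series so far is therefore set by the limit of > 500000 nM in this assay, at which 1 of the 2 values shown sits, with compound 1 standing alone as a measured inhibitor.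

Compound 3, `O=C(COc1ccc2cc(C(O)(C(F)(F)F)C(F)(F)F)c(O)cc2c1)Nc1cccc2ccccc12`, has not yet been measured. It keeps the core and the amide arm of compound 1 and differs in one place: naphthalen-1-yl in place of 4-phenylphenyl on an amide-type nitrogen. Within the data shown here, no measured pair in the set spans a change of this kind, so the size of the step has to be estimated. Both the group that leaves and the group that enters are two fused or joined six-membered carbon rings of similar bulk, so a modest step is expected, if anything towards a weaker inhibitor, and possibly within the usual scatter: a 1.6-fold higher number from compound 1 to compound 3 (0.21 log units; within the scatter). For compound 3 the expected value in this assay is 4500 nM, with a range from 1500 nM to 14000 nM.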

Compound 3, half-maximal inhibitory concentration: > 20000 nM
Compound 3 was reported as a limit; the forecaster's own chance of this, stated with the estimate: 5%; at least 4.4-fold (0.64 log units) between middle value and limit.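

In this assay, the result shows that the group on the amide-type nitrogen is not interchangeable, even between two close relatives: naphthalen-1-yl in place of 4-phenylphenyl gives an at least 7.1-fold higher number from compound 1 to compound 3 (0.85 log units; beyond the scatter). Going by these compounds alone, neither earlier compound offered any view of this position, and this step is the first reading of it. The two groups have the same counts of six-membered aromatic carbon rings, hydrogen-bond donors and hydrogen-bond acceptors and differ in heavy atoms, with fewer in naphthalen-1-yl than in 4-phenylphenyl, so those ring and donor and acceptor counts alone do not account for the loss, and the entry for compound 3 is a limit and not a number: the limit of > 20000 nM in this assay, at which 1 of the 3 values shown sits.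

The compounds shown leave open how much weaker compound 3 really is and whether the loss follows from the change in size, in shape or in the point of attachment, since a single step cannot separate these. Nor do they tell how a plain phenyl, a naphthalen-2-yl or a 4-phenylphenyl carrying a carboxylic acid would read at this position.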